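The compounds below may be only part of what the source reports. "The series", "measured", "known", "first", "only" and "open" are said of these compounds alone.

Compound 2 `COc1cc(Cc2cnc(/N=C3\C(=O)N(CN4CCC(C)CC4)c4ccc(Cl)cc43)nc2N)cc(OC)c1OC` has the lowest of the two numbers measured here, and in an ADME assay on MT4 cells (Homo sapiens) for cytotoxicity, read by MTT assay, with a stated time of 5 days (on this read-out lower numbers stand for higher toxicity in this test and higher numbers for lower toxicity in this test), compound 2 gives 67.4 ug/mL. Its nearest neighbour is compound 1 `COc1cc(Cc2cnc(/N=C3\C(=O)N(CN4CCCCC4C)c4ccc(Cl)cc43)nc2N)cc(OC)c1OC`, which in this assay gives 97.3 ug/mL; the step of a 1.4-fold lower number from compound 1 to compound 2 (0.16 log units; within the scatter) lies within the scatter, so the two compounds cannot be told apart on this read-out.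

Compound 3 `CCCCN(CCCC)CN1C(=O)/C(=N\c2ncc(Cc3cc(OC)c(OC)c(OC)c3)c(N)n2)c2cc(Cl)ccc21` has not yet been measured. It differs from compound 2 in one place: dibutylamino in place of 4-methylpiperidin-1-yl on a saturated chain carbon bound to an amide-type nitrogen in a ring. Going by the values given here, the only measured step, from compound 1 to compound 2, also alters the group on that same saturated chain carbon, but only by moving a methyl on the ring; it bears on the new step only loosely, and it was within the scatter.

With nothing pointing to a larger shift, compound 3 is expected to give about 55 ug/mL in this assay, within a range from 25 ug/mL to 120 ug/mL. The step this estimate means, a 1.2-fold lower number from compound 2 to compound 3 (0.09 log units; within the scatter), is expected to stay within the scatter.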

Compound 3, half-maximal cytotoxic concentration: 62.6 ug/mL
The estimate for compound 3 lay 1.1-fold (0.06 log units) below the measured number, within the range that was stated.
By their numbers in this assay, from the lowest: compounds 3, 2 and 1 (each within the scatter of the next).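

Earlier, only a methyl moved around a piperidine ring; here the ring itself gives way to the open-chain dibutylamino on the saturated chain carbon, and in this assay the result is a 1.1-fold lower number from compound 2 to compound 3 (0.03 log units; within the scatter). Set against the 2-methylpiperidin-1-yl group, the same exchange gives a 1.6-fold lower number from compound 1 to compound 3 (0.19 log units; within the scatter), so on this read-out the three compounds cannot be told apart, whether the amine at this position has a ring or two open butyl chains. No measurement shown offers a reason for this.

As far as these compounds go, all three groups are built only from carbon around a single nitrogen, so it remains open whether morpholin-4-yl, with a ring oxygen, the much shorter dimethylamino or a carboxylic acid at this position would give a step beyond the scatter.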